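Adding an Amino Group to Compound 1

The source may report more compounds than this note shows. Statements on the series, on what has been measured and on what is new or still open speak of the compounds shown alone.

Within the data shown here, in a physicochemical assay for lipophilicity, read by HPLC, at pH 7.5 (on this read-out lower numbers stand for lower lipophilicity and higher numbers for higher lipophilicity), compound 1 `CCOc1ccccc1-c1ccc(-c2nc3cnccc3cc2C#N)cc1` gives 3.8, the higher of the two numbers measured so far. Compound 2 `CC[C@@H](Nc1c(C#N)c(-c2ccc(-c3cccc(C)c3F)cc2)nc2cnccc12)C(N)=O` gives 3, lower by more than the usual scatter, but it differs from compound 1 in more than one place, so no measured single change is available as a guide. Compound 3 `CCOc1ccccc1-c1ccc(-c2nc3cnccc3c(N)c2C#N)cc1` has one change from compound 1: amino in place of hydrogen on an aromatic carbon, with amino in place of hydrogen on an aromatic carbon, ortho to a cyano group. A downward a number 0.50 log units lower from compound 1 to compound 3 (beyond the scatter) is expected, modestly beyond the scatter. For compound 3, the estimated value is 3.3, with an expected range of 2.8 to 3.8.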

Compound 3, distribution coefficient: 3
Compound 3: middle estimate off by 0.30 log units, on the high side; low and high end bracket the measured number.
By their numbers in this assay, from the lowest: compounds 2 and 3 (each within the scatter of the next); then compound 1.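

In this assay, amino in place of hydrogen on an aromatic carbon, ortho to a cyano group, gives a number 0.80 log units lower from compound 1 to compound 3 (beyond the scatter) and so provides the first step tied to a single change. The earlier compounds shown here differ in more than one place, so they could not tie any shift to this position alone. No available evidence bears on what lies behind this step. As far as these compounds go, whether a methylamino or an acetamido group at this position would give a step of similar size remains open, as does whether the amino group would give the same step without the neighbouring cyano group.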